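The source may hold more compounds than are shown below. What is called first, only, known or untested is meant among the compounds shown, and "the series" means these compounds.

Working notes on the series. Compound 1 `CCN(CC)C(=O)c1ccccc1OCC1=NCCN1`, compound 2 `c1cncc(-c2ccccc2OCC2=NCCN2)c1` and compound 3 `c1cnc(-c2ccccc2OCC2=NCCN2)nc1` have been run in a functional assay for activation of Alpha-1D adrenergic receptor (Homo sapiens), read by calcium flux; a higher number here means that more compound is needed for the effect, a lower number that less compound is needed; compound 4 `c1ccc(-c2ccncn2)c(OCC2=NCCN2)c1` has not. In this assay compound 2 gives 158 nM. For compound 1 only a limit of this assay is recorded, < 5020 nM. For compound 3 likewise only a limit of this assay is recorded, < 100000 nM. Compound 3 therefore cannot be placed on the scale beyond that limit, and the change from compound 2, a step that the limit leaves unreadable from compound 2 to compound 3, stays unreadable because compound 3 sits at the limit of < 100000 nM in this assay, at which 1 of the 3 values shown sits. Compound 1 sits at the limit of < 5020 nM in this assay, at which 1 of the 3 values shown sits.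

Compound 4 differs from compound 3 by pyrimidin-4-yl in place of pyrimidin-2-yl on an aromatic carbon. Going by the values given here, the one measured step that touches this position, a step that the limit leaves unreadable from compound 2 to compound 3, has no readable size, so no measured step gives a size or a direction for the move to compound 4 in this assay. What remains is that compound 2, carrying the pyridin-3-yl group, reaches 158 nM. Compound 3, carrying the pyrimidin-2-yl group, is known in this assay only as a limit. The expectation for compound 4 is left wide. Compound 4 is expected near 3000 nM, within 200 nM to 40000 nM, which is an estimated step that the limit leaves unreadable from compound 3 to compound 4 and carries a fair chance of again returning only a limit.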

Compound 4, half-maximal effective concentration: < 100000 nM
Compound 4 was reported as a limit; the forecaster's own chance of this, stated with the estimate: 30%; the middle value does not contradict the limit.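

No new step can be read: the moves to compound 4 from compound 3 and from compound 2 both stay unreadable, as compound 4 joins compound 3 as a limit in this assay: the limit of < 100000 nM in this assay, at which 2 of the 4 values shown sit.

Still open, going by these compounds, is how the pyrimidin-2-yl and pyrimidin-4-yl groups compare with each other, or with the pyridin-3-yl group of compound 2, in this assay.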